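The compounds below may be only part of what the source reports. "The series", "measured", "known", "first", "only" and "open" are said of these compounds alone.

Of the compounds shown here, three sharing one core have been tested in a functional assay for inhibition, with Rattus norvegicus as the target; a lower number here means a stronger inhibitor, a higher number a weaker inhibitor. Compound 1 `CC(C)(C)/N=c1\c(O)c(O)\c1=N/c1cccnc1` gives 2800 nM, compound 2 `COc1ccc(Nc2c(NC(C)C(C)(C)C)c(=O)c2=O)cc1` gives 2400 nM, and compound 3 `CC(C)(C)/N=c1\c(O)c(O)\c1=N/c1ccc(C#N)cc1` gives 560 nM. Compound 3 therefore stands at the lowest number of the three, and its gaps to compound 2 and to compound 1 both lie beyond the usual scatter. Compound 4 `C[C@H](/N=c1\c(O)c(O)\c1=N/c1ccc(C#N)cc1)c1ccccc1` has not been measured. It differs from compound 3 in one place: 1-phenylethyl in place of tert-butyl on a double-bonded nitrogen. Among the compounds with values here, no pair of measured compounds shows the effect of such a change, so the expectation rests on compound 3 alone. The step is expected to be small, leaning toward a weaker inhibitor, a 1.6-fold higher number from compound 3 to compound 4 (0.21 log units; within the scatter). In this assay compound 4 is estimated at 900 nM, with a range from 250 nM to 3500 nM.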

Compound 4, half-maximal inhibitory concentration: > 30000 nM
Compound 4: no number, only a limit; the forecaster's own chance of this, stated with the estimate: 5%; at least 33-fold (1.52 log units) between middle value and limit.
By their numbers in this assay, from the lowest: compound 3; then compounds 2 and 1 (each within the scatter of the next). At a limit, above all of these: compound 4.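

In this assay compound 4 gives > 30000 nM, which is a limit of the assay and not a number. The earlier compounds shown here offered no step at this place on the double-bonded nitrogen, and it now proves far from indifferent: 1-phenylethyl in place of tert-butyl gives an at least 53-fold higher number from compound 3 to compound 4 (1.72 log units; beyond the scatter). The compounds shown do not separate the contributions of the six-membered aromatic ring, the added carbons and the defined stereocentre. As far as these compounds go, how benzyl, cyclohexyl or the mirror-image 1-phenylethyl group would fare at this place remains open.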